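Sulfonamide anilides: swapping the naphthyl ether group

The source may hold more compounds than are shown below. What is called first, only, known or untested is meant among the compounds shown, and "the series" means these compounds.

Measured in an ADME assay on C8166 cells (Homo sapiens) for cytotoxicity, read by MTT assay; a higher number here means that more compound is tolerated, a lower number that less compound is tolerated:
compound 1 `Cc1cc(S(N)(=O)=O)ccc1NC(=O)COc1ccc(F)cc1Oc1cccc2ccccc12` gives 33100 nM
compound 2 `Cc1cc(S(N)(=O)=O)ccc1NC(=O)COc1ccc(Cl)cc1Oc1ccc2ccccc2c1Cl` gives 40700 nM
compound 3 `Cc1cc(S(N)(=O)=O)ccc1NC(=O)COc1ccc(Cl)cc1Oc1ccc2ccccc2c1Br` gives 48100 nM

The three compounds share one core and differ only in the halogen on the middle ring and in the naphthyl ether group. Compound 1 has the lowest of the three numbers, yet its nearest neighbour compound 2 and its furthest neighbour compound 3 both lie within the scatter of it, so no ordering among them can be claimed. Going by the values given here, the only single-point step measured, a 1.2-fold higher number from compound 2 to compound 3 (0.07 log units; within the scatter), is likewise within the scatter.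

Compound 4 `Cc1cc(S(N)(=O)=O)ccc1NC(=O)COc1ccc(F)cc1Oc1cc2ccccc2cc1C` is built from compound 1 by the change (3-methylnaphthalen-2-yl in place of naphthalen-1-yl on an oxygen on an aromatic ring). Among the compounds with values here, no measured step touches this kind of change, and the one halogen step that exists is flat, so a result within the scatter is expected in this assay, with no direction favoured. The expected step is a 1.1-fold higher number from compound 1 to compound 4 (0.06 log units; within the scatter). Compound 4 is estimated at 38000 nM, with a range from 19000 nM to 76000 nM.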

Compound 4, half-maximal cytotoxic concentration: 66900 nM
The estimate for compound 4 lay 1.8-fold (0.25 log units) below the measured number; low and high end bracket the measured number.
By their numbers in this assay, from the lowest: compounds 1, 2, 3 and 4 (each within the scatter of the next, the first and the last beyond it).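

In this assay, 3-methylnaphthalen-2-yl in place of naphthalen-1-yl on the oxygen gives a 2.0-fold higher number from compound 1 to compound 4 (0.31 log units; beyond the scatter), a modest step but the first one here beyond the scatter. Going by these compounds alone, the only earlier step, a halogen swap on the naphthyl ether group, stayed within the scatter, so this is the first sign that changing that group can shift how much compound the cells tolerate. Nothing available here explains this step.

This single change both adds a methyl and alters how the naphthalene is attached, so the part each plays remains unresolved; plain naphthalen-2-yl would separate the two. Also open, from the compounds shown here alone, is how the number would respond to an amine or a carboxylic acid on this group, or to a longer chain in place of the methyl.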